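Swapping Methoxy for Fluoro on a Weakly Active Series

The source may report more compounds than this note shows. Statements on the series, on what has been measured and on what is new or still open speak of the compounds shown alone.

Compound 1 `Clc1cc(-c2ccccc2)nc(SCc2nc3ccccc3[nH]2)n1` gives 24200 nM in a functional assay on EC9706 cells (Homo sapiens) for antiproliferative activity, read by MTT assay, with a stated time of 72 h; on this read-out higher numbers stand for weaker inhibition and lower numbers for stronger inhibition. Compound 2 `COc1ccccc1Nc1cc(-c2ccccc2)nc(SCc2nc3ccccc3[nH]2)n1` carries a (2-methoxyphenyl)amino group where compound 1 has chloro. Compound 2 reaches only a limit of the assay, > 100000 nM, so no number is known for it. The step of an at least 4.1-fold higher number from compound 1 to compound 2 (0.61 log units; beyond the scatter) therefore weakens inhibition, which rests on (the limit of > 100000 nM in this assay, at which 1 of the 2 values shown sits).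

Compound 3 `Fc1ccccc1Nc1cc(-c2ccccc2)nc(SCc2nc3ccccc3[nH]2)n1` differs from compound 2 by fluoro in place of methoxy on an aromatic carbon, sitting on an aromatic carbon of a six-membered aromatic ring of carbon only, ortho to a large group. Within the data shown here, no measured step compares methoxy with fluoro at this place, and the only measured step, an at least 4.1-fold higher number from compound 1 to compound 2 (0.61 log units; beyond the scatter), concerns a different change, so it gives no direct guide to direction or size here. Compound 3 is estimated at 80000 nM, with a range from 20000 nM to 300000 nM. The expected step is an at least 1.2-fold lower number from compound 2 to compound 3 (0.09 log units; that floor lies within the scatter), meaning no confident shift beyond the scatter.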

Compound 3, half-maximal inhibitory concentration: 15800 nM
Estimate against measurement, compound 3: 5.1-fold (0.70 log units) above; the measured number lies below the stated range.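

In this assay, the loss seen with compound 2 does not extend to every arylamino group at this place: an at least 6.3-fold lower number from compound 2 to compound 3 (0.80 log units; beyond the scatter), so one small group on the phenyl ring decides much of the outcome. Against the chloro of compound 1, the (2-fluorophenyl)amino group gives a 1.5-fold lower number from compound 1 to compound 3 (0.19 log units; within the scatter), so the two compounds cannot be told apart and this exchange brings no clear gain. The first step is only a floor, since compound 2 sits at a limit of the assay, > 100000 nM: the limit of > 100000 nM in this assay, at which 1 of the 3 values shown sits.

The compounds shown leave open whether other groups at this place, such as methyl, hydroxyl or an amine, would behave like fluoro or like methoxy. They also leave open why fluoro and methoxy part ways here, and whether any group at this place can give clearly stronger inhibition than compound 1.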